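Chloromethyl-pyridyl ketone and a carboxybutyl replacement

The source may hold more compounds than are shown below. What is called first, only, known or untested is meant among the compounds shown, and "the series" means these compounds.

Among the compounds with values here, compound 1 `O=C(CCCCCCc1ccccc1)c1ncc(-c2ccc(CCl)cn2)o1` is one of two compounds measured in an assay for inhibition of Fatty-acid amide hydrolase 1 (Rattus norvegicus), using a Dixon plot; on this read-out higher numbers stand for weaker inhibition and lower numbers for stronger inhibition. In this assay compound 1 gives 22.4 nM, the highest of the two numbers shown. Within the data shown here, its single neighbour, compound 2 `N#C/C=C/c1ccc(-c2cnc(C(=O)CCCCCCc3ccccc3)o2)nc1`, gives 2.1 nM; the step of an 11-fold lower number from compound 1 to compound 2 (1.03 log units; beyond the scatter) is the only measured one, and it shows that a change at this end of the molecule can move the number a long way.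

Compound 3 `O=C(O)CCCCc1cnc(C(=O)CCCCCCc2ccccc2)o1` has not yet been measured. It differs from compound 1 by a group of 7 heavy atoms (5 carbon, 2 oxygen; no ring) in place of a group of 8 heavy atoms (6 carbon, 1 nitrogen, 1 chlorine; one six-membered aromatic ring with 1 hetero atom), on an aromatic carbon. The replacement takes place on an aromatic carbon of the five-membered aromatic ring with one nitrogen and one oxygen of the shared core. Among the measured compounds shown here, no measured pair shows a ring being exchanged for an open chain carrying a carboxylic acid, so the step from compound 1 to compound 2 bears on it only as a sign of how sensitive this position is. He therefore expects a sizeable step in this assay, toward a higher number, a 13-fold higher number from compound 1 to compound 3 (1.13 log units; beyond the scatter), and estimates compound 3 at 300 nM, with a range from 50 nM to 3000 nM.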

Compound 3, inhibition constant: 23.8 nM
Estimate against measurement, compound 3: 13-fold (1.10 log units) above; the measured number lies below the stated range.
By their numbers in this assay, from the lowest: compound 2; then compounds 1 and 3 (each within the scatter of the next).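

In this assay, replacing the six-membered aromatic ring and its chloromethyl group with 4-carboxybutyl gives a 1.1-fold higher number from compound 1 to compound 3 (0.03 log units; within the scatter) and so leaves the number within the scatter. The step of an 11-fold lower number from compound 1 to compound 2 (1.03 log units; beyond the scatter) concerned only the group carried on that six-membered ring, while this one shows that, on the aromatic carbon next to the ring oxygen, an open chain ending in a carboxylic acid can stand in place of the whole ring-bearing group. The sensitivity seen in the first step therefore does not extend to this exchange, and a six-membered aromatic ring at this place is not required for a number at the level of compound 1. No measurement shown here explains why these two different groups give numbers within the scatter of each other.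

The compounds shown leave open whether the carboxylic acid or the chain that carries it matters more here, a question that a methyl ester or a plain pentyl chain at this place would help to separate. Also open, from the compounds shown here alone, is how the number would respond to a shorter or longer chain ending in a carboxylic acid, or to a chain ending in an amine.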